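From carboxy to ethoxycarbonyl on compound 3

The source may hold more compounds than are shown below. What is called first, only, known or untested is meant among the compounds shown, and "the series" means these compounds.

Of the compounds shown here, three with a shared core have been measured in a physicochemical assay for lipophilicity, measured as octanol-water partition (a higher number here means a more lipophilic compound, a lower number a more polar compound), and they differ only in the group on a saturated chain carbon. Compound 1 `CC(=O)N[C@H](C(=O)N1C[C@H](O)C[C@H]1C(=O)N[C@@H](CCC(C)(C)C)c1ccc(-c2scnc2C)cc1)C(C)(C)C`, carrying tert-butyl, gives 3.21. Compound 2 `CC(=O)N[C@H](C(=O)N1C[C@H](O)C[C@H]1C(=O)N[C@@H](CCc1ccc(Br)cc1)c1ccc(-c2scnc2C)cc1)C(C)(C)C`, carrying 4-bromophenyl, gives 4.08. Compound 3 `CC(=O)N[C@H](C(=O)N1C[C@H](O)C[C@H]1C(=O)N[C@@H](CCC(=O)O)c1ccc(-c2scnc2C)cc1)C(C)(C)C`, carrying carboxy, gives 1.02, the lowest number of the three.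

Compound 4 `CCOC(=O)CC[C@H](NC(=O)[C@@H]1C[C@@H](O)CN1C(=O)[C@@H](NC(C)=O)C(C)(C)C)c1ccc(-c2scnc2C)cc1` differs from compound 3 in one place: ethyl in place of hydrogen on an oxygen next to a carbonyl group. Carboxy thus becomes ethoxycarbonyl.

Within the data shown here, two measured steps bear on this change, since both end at the carboxy group of compound 3: a number 2.19 log units lower from compound 1 to compound 3 (beyond the scatter) and a number 3.06 log units lower from compound 2 to compound 3 (beyond the scatter). Both are large and beyond the scatter. Among the measured compounds shown here, neither is the same change as this one, so the data offer no direct precedent for ethoxycarbonyl. Still, compound 4 no longer has the carboxy group that sits at the low end of both steps, so a large rise in this assay is expected, probably stopping near the number of compound 1. The expected change is a number 1.68 log units higher from compound 3 to compound 4 (beyond the scatter). Compound 4 is estimated at 2.7, with an expected range from 2.1 to 3.3.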

Compound 4, partition coefficient: 1.59
For compound 4 the middle estimate is 1.11 log units above the measured one, and the stated range ends above it.
By their numbers in this assay, from the lowest: compound 3; then compound 4; then compound 1; then compound 2.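

In this assay, putting ethyl on the oxygen does lift the number (a number 0.57 log units higher from compound 3 to compound 4 (beyond the scatter)), but the step is modest, and ethoxycarbonyl stays well short of the two non-acid groups at this saturated chain carbon, tert-butyl (a number 1.62 log units lower from compound 1 to compound 4 (beyond the scatter)) and 4-bromophenyl (a number 2.49 log units lower from compound 2 to compound 4 (beyond the scatter)). Replacing the carboxy hydrogen alone therefore does not bring this position up to the level of compound 1, and in these four compounds ethoxycarbonyl sits much nearer to carboxy than to either of the other two groups. No separate measurement is available to explain why the step from carboxy to ethoxycarbonyl has this size.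

As far as these compounds go, it remains open whether a longer chain on the same oxygen, such as butoxycarbonyl, would move the number further towards compound 1 or leave it close to compound 4. A primary carboxamide or a hydroxymethyl group at the same chain carbon would show whether other groups also fall in the low range occupied by carboxy and ethoxycarbonyl.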